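Replacing the propargyloxyphenyl arm of a cinnamamide benzophenone

The source may hold more compounds than are shown below. What is called first, only, known or untested is meant among the compounds shown, and "the series" means these compounds.

The shared core of this series is the aminobenzophenone `COc1ccc(C(=O)c2cc(OC)c(OC)c(OC)c2)cc1N`, compound 1, which in a functional assay on COLO 205 cells (Homo sapiens) for cytotoxicity, read by MTT assay, with a stated time of 72 h (on this read-out lower numbers stand for stronger inhibition and higher numbers for weaker inhibition), gives 200 nM. Acylation of the amine with a trimethoxycinnamoyl chain yields compound 2, `COc1ccc(C(=O)c2cc(OC)c(OC)c(OC)c2)cc1NC(=O)/C=C/c1cc(OC)c(OC)c(OC)c1`, and in this assay compound 2 gives 5200 nM. Compound 3, `C#CCOc1cccc(/C=C/C(=O)Nc2cc(C(=O)c3cc(OC)c(OC)c(OC)c3)ccc2OC)c1`, carries a propargyloxyphenyl group on the same chain and in this assay compound 3 gives 13400 nM, the highest number among the three measured compounds; the step of a 2.6-fold higher number from compound 2 to compound 3 (0.41 log units; beyond the scatter) separates it from its nearest neighbour, and its gap to compound 1 is far wider.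

Compound 4, `COc1cc(/C=C/C(=O)Nc2cc(C(=O)c3cc(OC)c(OC)c(OC)c3)ccc2OC)ccc1F`, is the next variation: 4-fluoro-3-methoxyphenyl in place of 3-(propargyloxy)phenyl on a double-bonded chain carbon bound to a double-bonded chain carbon. Within the data shown here, the only measured step that bears on this position is a 2.6-fold higher number from compound 2 to compound 3 (0.41 log units; beyond the scatter), which shows that the identity of this aryl group moves the number modestly. Compound 4 carries a methoxy group on that ring, as compound 2 does, but also a fluorine, so it is expected to sit between compound 2 and compound 3 rather than to return to the number of compound 1. The expected step is a 1.9-fold lower number from compound 3 to compound 4 (0.28 log units; within the scatter), a modest lowering. Compound 4 is therefore estimated at 7000 nM, within a range from 2800 nM to 17000 nM.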

Compound 4, half-maximal inhibitory concentration: 11800 nM
For compound 4 the middle estimate is 1.7-fold (0.23 log units) below the measured one, within the range that was stated.
By their numbers in this assay, from the lowest: compound 1; then compound 2; then compounds 4 and 3 (each within the scatter of the next).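

In this assay the step of a 1.1-fold lower number from compound 3 to compound 4 (0.06 log units; within the scatter) lies within the scatter, so on a double-bonded chain carbon bound to a double-bonded chain carbon, 4-fluoro-3-methoxyphenyl and 3-(propargyloxy)phenyl cannot be told apart, even though one arm carries a fluorine and the other a triple bond. The step of a 2.3-fold higher number from compound 2 to compound 4 (0.36 log units; beyond the scatter) lies beyond the scatter and is modest, so with two arms now set against 3,4,5-trimethoxyphenyl, compound 2 keeps a lower number than either, and the earlier gap to compound 3 no longer stands alone. What the series now shows at this position is a small separation of compound 2 from a pair of compounds that sit level, and no measurement offered here accounts for that separation.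

The compounds shown leave open whether any arm at this place can bring a cinnamamide close to compound 1 at 200 nM in this assay. They also do not tell how an arm bearing an amine or a carboxylic acid, a plain phenyl, or a longer chain ahead of the ring would read in this assay on this scale.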